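This account rests on a few compounds, and the source may have more. Where it says the series, first, only, none or still open, it means among the compounds named here.

In a functional assay on MCF7 cells (Homo sapiens) for cytotoxicity, read by MTT assay, with a stated time of 72 h (a lower number here means a stronger inhibitor, a higher number a weaker inhibitor), compound 1, `O=C1C(=Cc2ccc(Cl)cc2)C(=O)N(c2ccc(Cl)cc2)N1c1ccc(Cl)cc1`, gives 28500 nM. Compound 2, `COc1cc(C=C2C(=O)N(c3ccc(Cl)cc3)N(c3ccc(Cl)cc3)C2=O)cc(OC)c1OC`, gives 16200 nM, and compound 3, `COc1cccc(C=C2C(=O)N(c3ccc(Cl)cc3)N(c3ccc(Cl)cc3)C2=O)c1`, gives 18100 nM. Compound 3 therefore stands close to compound 2, and its gaps to both other compounds lie within the usual scatter, so these numbers do not rank the three.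

Compound 4, `COc1ccc(C=C2C(=O)N(c3ccc(Cl)cc3)N(c3ccc(Cl)cc3)C2=O)cc1OC`, differs from compound 3 in one place: methoxy in place of hydrogen on an aromatic carbon. Put simply, this is methoxy in place of hydrogen on an aromatic carbon, ortho to a methoxy group and para to a large group, turning 3-methoxyphenyl into 3,4-dimethoxyphenyl.

Within the data shown here, no measured step makes exactly this change. Among the measured compounds shown here, the one measured step, a 1.6-fold lower number from compound 1 to compound 3 (0.20 log units; within the scatter), replaces 4-chlorophenyl with 3-methoxyphenyl and stays within the scatter. Compound 2 offers a further clue, as it carries more methoxy groups on that aromatic ring than compound 3. Even so, the two values lie within the scatter of each other, with compound 2 at 16200 nM.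

No change beyond the scatter is therefore expected in this assay, and the estimated step is a 1.1-fold lower number from compound 3 to compound 4 (0.03 log units; within the scatter). Compound 4 is expected to give about 17000 nM, with an estimated range from 9500 nM to 30000 nM.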

Compound 4, half-maximal inhibitory concentration: > 128000 nM
Compound 4 gave a limit, no number; the forecaster's own chance of this, stated with the estimate: 3%; at least 7.5-fold (0.87 log units) between middle value and limit.
By their numbers in this assay, from the lowest: compounds 2, 3 and 1 (each within the scatter of the next). At a limit, above all of these: compound 4.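

Up to now, swapping or adding groups on this aromatic ring had moved the number only within the scatter, but in this assay a single methoxy on the carbon ortho to a methoxy group and para to a large group gives an at least 7.0-fold higher number from compound 3 to compound 4 (0.84 log units; beyond the scatter). Compound 2 carries this same methoxy plus one more on the ring, and replacing that extra methoxy with hydrogen gives an at least 7.9-fold higher number from compound 2 to compound 4 (0.89 log units; beyond the scatter), so the number of methoxy groups alone does not order these compounds: compound 3 with fewer and compound 2 with more both go against any simple trend. The step of an at least 4.4-fold higher number from compound 1 to compound 4 (0.65 log units; beyond the scatter) shows that 3,4-dimethoxyphenyl also stands apart from 4-chlorophenyl, so the arrangement of groups on this ring matters here, not just the presence of a methoxy.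

Compound 4 has a limit and not a number, so the true size of all three steps stays unknown: the limit of > 128000 nM in this assay, at which 1 of the 4 values shown sits. The compounds shown also leave open whether a smaller hydroxy group, an amine or a longer ethoxy chain on this same carbon would behave like this methoxy.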